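Carbamoyl in Place of Carboxy: Expectation for Compound 3

The compounds below may be only part of what the source reports. "The series", "measured", "known", "first", "only" and "open" are said of these compounds alone.

Compound 1, `NC(=O)CNC(=O)C(CSCc1ccc(Br)cc1)NC(=O)CCC(N)C(N)=O`: in a functional assay on K562 cells (Homo sapiens) for cytotoxicity (a lower number here means a stronger inhibitor, a higher number a weaker inhibitor), compound 1 gives > 50 uM, which is a limit of the assay and not a number.
Compound 2, `NC(=O)CNC(=O)C(CSCc1ccc(Br)cc1)NC(=O)CCC(NC(=O)OCc1ccccc1)C(=O)O`: in this assay compound 2 gives > 50 uM, again a limit of the assay rather than a number.

Compound 2 therefore stands at no measured number at all; both values shown sit at the limit of > 50 uM in this assay, at which 2 of the 2 values shown sit. Going by the values given here, no step between measured compounds is available, since the two measured compounds differ in more than one place, and compound 1 can only be said to share that limit.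

Compound 3, `NC(=O)CNC(=O)C(CSCc1ccc(Br)cc1)NC(=O)CCC(NC(=O)OCc1ccccc1)C(N)=O`, differs from compound 2 by amino in place of hydroxy on a carbonyl carbon; cut one bond further out, the change reads carboxy to carbamoyl. Among the compounds with values here, with both known values at the limit, there is no measured step that could point in either direction. The step from compound 2 to compound 3 is expected to stay within the scatter, a step that the limit leaves unreadable from compound 2 to compound 3, and most likely the assay would again report only a limit. Compound 3 is accordingly estimated at 60 uM, with an expected range from 20 uM to 200 uM.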

Compound 3, concentration for 50% inhibition: > 50 uM
Compound 3: no number, only a limit (the forecaster's own chance of this, stated with the estimate: 80%); the middle value is on the limit's open side.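

In this assay compound 3 gives > 50 uM, which is a limit of the assay and not a number. Going by these compounds alone, no step from compound 1 or compound 2 to compound 3 can be read, and all three compounds share one limit: the limit of > 50 uM in this assay, at which 3 of the 3 values shown sit. The compounds shown leave open what size, if any, the change from carboxy to carbamoyl has in this assay.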